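Series notes: fluoro for chloro, compound 1 to compound 4

A few compounds are considered here, and "the series" means these few. Any claim that something is new, unique, unknown or untested is made for them only; others in the source may bear on it.

Measured in a functional assay on MDA-MB-231 cells (Homo sapiens) for inhibition; a lower number here means a stronger inhibitor, a higher number a weaker inhibitor:
compound 1 (`O=C(/C=C/c1ccc(F)c(Cl)c1)c1ccc(B(O)O)cc1`): 8500 nM
compound 2 (`O=C(O)COc1ccc(/C=C/C(=O)c2ccc(Cl)c(Cl)c2)cc1`): 18000 nM
compound 3 (`O=C(/C=C/c1ccc(I)cc1)c1ccc(O)cc1`): 8000 nM

Of the compounds shown here, three have numbers in this assay so far. Compound 1 stands second highest of the three. Compound 3 lies nearest to it, and the two values sit within the scatter of each other, so nothing separates them. Compound 2 gives a higher number than compound 1, a gap beyond the scatter. Within the data shown here, no two of the measured compounds differ in one place only, so no single-change step is known from which to read the weight of a small substituent swap.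

Compound 4 (`O=C(/C=C/c1ccc(F)c(F)c1)c1ccc(B(O)O)cc1`) is the next to be measured. It differs from compound 1 in one place: fluoro in place of chloro on an aromatic carbon. Fluoro in place of chloro on an aromatic carbon is a small change, and with no measured step to lean on, the expectation is a step from compound 1 to compound 4 of a 1.2-fold higher number from compound 1 to compound 4 (0.07 log units; within the scatter), meaning none beyond the scatter, if anything toward a slightly higher number. Compound 4 is accordingly estimated at 10000 nM, with a range of 4000 nM to 25000 nM.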

Compound 4, half-maximal inhibitory concentration: 8800 nM
Compound 4: the middle estimate sits 1.1-fold (0.06 log units) above what was measured; the range from low to high includes it.
By their numbers in this assay, from the lowest: compounds 3, 1 and 4 (each within the scatter of the next); then compound 2.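

In this assay, the series now has its first single-change step: fluoro in place of chloro on an aromatic carbon, ortho to a fluoro group and meta to a large group (a 1.0-fold higher number from compound 1 to compound 4 (0.02 log units; within the scatter)). On the core of compound 1, this step gives no sign that chloro rather than fluoro matters at this position, as the change stays within the scatter. No measurement at hand offers an explanation for this result.

The compounds shown leave open whether a group other than a halogen, such as an amine, a methoxy group or a nitrile, would keep the read-out at this level at this position. From the compounds shown here alone, the swap is also known only with the boronic acid in place, so its size on other versions of the core remains unknown.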